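Fluoro for Methoxy on the Sulfonyl Aryl Ring

A few compounds are considered here, and "the series" means these few. Any claim that something is new, unique, unknown or untested is made for them only; others in the source may bear on it.

Compound 1, `COc1cccc(-c2c(S(=O)(=O)c3ccc(OC)c(Cl)c3)cnc3cc(F)ccc23)c1`: 1.71 mL/min
Compound 2, `COc1ccc(S(=O)(=O)c2cnc3cc(F)ccc3c2-c2cccc(F)c2)cc1Cl`: 2.08 mL/min
Compound 3, `COc1ccc(-c2c(S(=O)(=O)c3ccc(OC)cc3)cnc3cc(F)ccc23)cc1`: 1.18 mL/min

These three compounds were measured in an ADME assay on microsomes from liver (Homo sapiens) for metabolic stability, tested at 2.5 uM; a lower number here means slower removal, a higher number faster removal of the compound. Compound 1 and compound 2 differ by fluoro in place of methoxy on an aromatic carbon, and this change gave a 1.2-fold higher number from compound 1 to compound 2 (0.09 log units; within the scatter). The difference between the core of compound 1 and the core of compound 3 is not broken down here. Compound 4, `COc1ccc(-c2c(S(=O)(=O)c3ccc(F)cc3)cnc3cc(F)ccc23)cc1`, has not yet been measured in this assay; it differs from compound 3 by fluoro in place of methoxy on an aromatic carbon. In compound 1 and compound 2 the place is meta to a large group, whereas in compound 3 and compound 4 it is para to a large group, so this is the same kind of change rather than the same change. Because compound 3 gives 1.18 mL/min and the earlier change gave a 1.2-fold higher number from compound 1 to compound 2 (0.09 log units; within the scatter), a similar small step is expected, namely a 1.2-fold higher number from compound 3 to compound 4 (0.07 log units; within the scatter). Compound 4 is therefore estimated at 1.4 mL/min, between 0.8 mL/min and 2.6 mL/min.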

Compound 4, intrinsic clearance in a liver preparation (reported as CLH), per the amount of preparation that the assay uses: 1.77 mL/min
Beside the measured number, compound 4's estimate is 1.3-fold (0.10 log units) below it; the range from low to high includes it.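

In this assay, fluoro in place of methoxy gave a 1.5-fold higher number from compound 3 to compound 4 (0.18 log units; within the scatter), and the two steps read alike across the two cores: the same change on two cores in this assay, a 1.2-fold higher number (0.09 log units; within the scatter) from compound 1 to compound 2 and a 1.5-fold higher number (0.18 log units; within the scatter) from compound 3 to compound 4, 1.2-fold (0.09 log units) apart, within the scatter of two such steps. On these two pairs, then, the change carried from the core of compound 1 to the core of compound 3 with no difference that stands out from the scatter. Both steps themselves lie within the scatter, however, so neither shows a real shift on its own core, and two pairs say nothing about any further core.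

The compounds shown leave open what an amine, a carboxylic acid or a longer alkoxy chain would do in that place in this assay. From the compounds shown here alone, whether the change would behave alike on a third core also stays open.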